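This account rests on a few compounds, and the source may have more. Where it says the series, first, only, none or still open, it means among the compounds named here.

Compounds measured so far in an ADME assay on a cell-free system (plasma, Mus musculus) for metabolic stability, read by HPLC, with a stated time of 120 min, tested at 2 uM; a lower number here means that the compound disappears faster, a higher number that the compound lasts longer:
- compound 1 `Cc1cccc(CNC(=O)n2cnc3ccccc32)c1` gives 1.18 h
- compound 2 `O=C(NCCCCc1ccccc1)n1ncc2ccccc21` gives > 2 h as a limit of the assay
- compound 3 `Cc1ccccc1CNC(=O)n1cnc2ccccc21` gives 0.733 h

Among the compounds with values here, compound 3 (0.733 h) and compound 1 (1.18 h) hold the only two numeric values, and these lie within the scatter of each other. The result for compound 2 (> 2 h) is a limit of the assay, not a number.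

Compound 4 `Cc1ccccc1CNC(=O)n1c(N)nc2ccccc21` has not been measured. It differs from compound 3 by amino in place of hydrogen on an aromatic carbon and otherwise keeps the same structure. Within the data shown here, no measured pair differs in one place, so no step size can be carried over. In this assay a change within the scatter is expected, with no direction favoured, starting from compound 3 (0.733 h). The expected step is a 1.1-fold higher number from compound 3 to compound 4 (0.04 log units; within the scatter) and remains an estimate. For compound 4 the estimated half-life is 0.8 h with an expected range of 0.35 h to 2 h.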

Compound 4, half-life: < 0.0834 h
Compound 4: only a limit was reported; the forecaster's own chance of this, stated with the estimate: 10%; at least 9.5-fold (0.98 log units) between middle value and limit.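

In this assay the series now has its first step in one place, amino in place of hydrogen on an aromatic carbon, and it reads an at least 8.7-fold lower number from compound 3 to compound 4 (0.94 log units; beyond the scatter) and so exceeds the scatter. The earlier compounds shown here could not show that this position, between two ring nitrogen atoms and next to the ring atom that bears a large group, responds to a change of 1 heavy atom. Going by these compounds, compound 4 gives < 0.0834 h, which is a limit of the assay and not a number, so the full size of the step stays open: the limit of < 0.0834 h in this assay, at which 1 of the 4 values shown sits.

On these data alone, whether the shorter half-life belongs to amino alone remains open; a methyl group, a hydroxyl group or a dimethylamino group at this position would test that. Also open, as far as these compounds go, is whether amino in this place gives a step of like size on compound 1.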